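Terminal aryl variation on a shared acid core

A few compounds are considered here, and "the series" means these few. Any claim that something is new, unique, unknown or untested is made for them only; others in the source may bear on it.

Measured so far:
compound 1 `CCc1ccccc1-c1cccc(COc2ccc([C@H](CC(=O)O)c3nccn3C)cc2)c1` — 65000 nM
compound 2 `Cc1cc(Cl)ccc1-c1cccc(COc2ccc([C@H](CC(=O)O)c3nccn3C)cc2)c1C` — 23000 nM

In an assay on CHO cells for agonist activity at Free fatty acid receptor 1 (Homo sapiens), read by luminescence, with a stated time of 20 s, in the presence of a further agent that is not named here (on this read-out lower numbers stand for an effect already at smaller amounts and higher numbers for an effect only at larger amounts of compound), compound 1 gives 65000 nM, the higher of the two numbers recorded, and the gap to compound 2 lies beyond the usual scatter. Compound 2, with 23000 nM, carries a chlorine and methyl groups where compound 1 carries ethyl, plus one additional methyl.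

Compound 3 `Cc1c(Cl)cccc1-c1cccc(COc2ccc([C@H](CC(=O)O)c3nccn3C)cc2)c1` awaits measurement. Relative to compound 1 the change is 3-chloro-2-methylphenyl in place of 2-ethylphenyl on an aromatic carbon. Within the data shown here, no measured pair differs in one place only, so no step can be counted directly. Compound 3 shares the chlorine-and-methyl substitution with compound 2 but lacks the additional methyl, and some movement towards compound 2 seems plausible because compound 2 gives 23000 nM. A modest step towards a lower number is therefore expected, a 1.9-fold lower number from compound 1 to compound 3 (0.27 log units; within the scatter), though a change within the scatter remains possible. Compound 3 is estimated at 35000 nM, with a range from 12000 nM to 100000 nM.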

Compound 3, half-maximal effective concentration: 22000 nM
For compound 3 the middle estimate is 1.6-fold (0.20 log units) above the measured one; the measured number falls inside the stated range.
By their numbers in this assay, from the lowest: compounds 3 and 2 (each within the scatter of the next); then compound 1.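

In this assay, among these compounds, the exchange of 2-ethylphenyl for 3-chloro-2-methylphenyl on an aromatic carbon, meta to a large group, gives a 3.0-fold lower number from compound 1 to compound 3 (0.47 log units; beyond the scatter) and provides the first step that can be read at a single place. The number at this position therefore responds to the substitution on the terminal aryl group, even though the two groups match in heavy-atom count and neither carries a hydrogen-bond donor or acceptor. Nothing measured here speaks to the origin of this step.

Steps to compound 2 cannot be read, as it differs from compound 1 and from compound 3 in more than one place. Open questions are whether the chlorine or the change from ethyl to methyl carries the step, and how an amine or a methoxy group on the terminal aryl group would read.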